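Cytotoxicity in the amide series: from compound 1 to compound 4

A few compounds are considered here, and "the series" means these few. Any claim that something is new, unique, unknown or untested is made for them only; others in the source may bear on it.

In an ADME assay on NCM460 cells (Homo sapiens) for cytotoxicity, read by MTT assay, with a stated time of 72 h (on this read-out higher numbers stand for weaker inhibition and lower numbers for stronger inhibition), compound 1 `Cc1ccc(NC(=O)c2cccc(/C=C3\CC(=O)N(c4ccccc4)C3=O)c2)cc1` gives > 100000 nM, a limit rather than a number. Compound 2 `Cc1ccc(N2C(=O)C/C(=C\c3cccc(C(=O)Nc4ccc(Cl)cc4)c3)C2=O)cc1` gives > 100000 nM, also a limit. Compound 3 `CCCCCN1C(=O)C/C(=C\c2cccc(C(=O)Nc3ccc(OC)cc3)c2)C1=O` gives > 100000 nM, again a limit. Compound 1 therefore cannot be placed against the others: all three measured values share (the limit of > 100000 nM in this assay, at which 3 of the 3 values shown sit). Compound 4 `CSc1cccc(NC(=O)c2cccc(/C=C3\CC(=O)N(c4ccccc4)C3=O)c2)c1` differs from compound 1 in one place: 3-(methylsulfanyl)phenyl in place of 4-methylphenyl on an amide-type nitrogen. No measured step exists between any two of these compounds in this assay, so the change has no measured precedent; the expectation is a step of no size beyond the scatter, in no particular direction, and the step is expected to be a step that the limit leaves unreadable from compound 1 to compound 4. Compound 4 is expected to give 150000 nM, with a range from 60000 nM to 400000 nM, most probably again reported only as a limit.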

Compound 4, half-maximal inhibitory concentration: > 100000 nM
Compound 4 ended at the assay's limit (the forecaster's own chance of this, stated with the estimate: 80%); the middle value is on the limit's open side.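

In this assay no step can be read between compound 1 and compound 4, as both sit at the same limit: the limit of > 100000 nM in this assay, at which 4 of the 4 values shown sit.

In this assay the compounds shown leave open whether any change on the shared core gives a readable number.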